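The source may hold more compounds than are shown below. What is called first, only, known or untested is meant among the compounds shown, and "the series" means these compounds.

Within the data shown here, in a functional assay on Malme-3M cells (Homo sapiens) (a lower number here means a stronger inhibitor of growth, a higher number a weaker inhibitor of growth), compound 1 `COc1cc(CSc2cc(Cl)c(-c3nnc(-c4ccc(Cl)cc4)s3)cc2S(=O)(=O)NC(=N)NO)cc(OC)c1OC` gives 97700 nM, the highest of the two numbers measured so far. Compound 2 `N=C(NO)NS(=O)(=O)c1cc(-c2nnc(-c3ccc(Cl)cc3)s2)c(Cl)cc1SCc1ccccc1` gives 1960 nM. Among the measured compounds shown here, the only measured step, a 50-fold lower number from compound 1 to compound 2 (1.70 log units; beyond the scatter), exchanges the group on the saturated chain carbon bound to a sulfur and leaves the shared core untouched. Compound 3 `COc1cc(CSc2cc(Cl)c(-c3nc(-c4ccccc4)no3)cc2S(=O)(=O)NC(=N)NO)cc(OC)c1OC` differs from compound 1 at another place: 3-phenyl-1,2,4-oxadiazol-5-yl in place of 5-(4-chlorophenyl)-1,3,4-thiadiazol-2-yl on an aromatic carbon. For the measured compounds named here, no measured step bears on this exchange, so neither direction can be read from the series. The expected step is therefore small, a 1.6-fold lower number from compound 1 to compound 3 (0.21 log units; within the scatter), with a wide range. Compound 3 is estimated at 60000 nM, between 15000 nM and 250000 nM.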

Compound 3, concentration for 50% growth inhibition: 13500 nM
For compound 3 the middle estimate is 4.4-fold (0.65 log units) above the measured one; measured number below the stated range.
By their numbers in this assay, from the lowest: compound 2; then compound 3; then compound 1.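

In this assay, the place on the aromatic carbon para to a large group also responds to exchange: 3-phenyl-1,2,4-oxadiazol-5-yl in place of 5-(4-chlorophenyl)-1,3,4-thiadiazol-2-yl gives a 7.2-fold lower number from compound 1 to compound 3 (0.86 log units; beyond the scatter). The exchange replaces the five-membered ring and removes the chlorine together, so the share of each cannot be separated. No available evidence bears on this step.

Going by these compounds, whether this step and a 50-fold lower number from compound 1 to compound 2 (1.70 log units; beyond the scatter) add up in a single compound remains open. Also open, on these data alone, is how an amine at the same aromatic carbon would compare.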